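A Methyl Added Twice in a Paw Edema Series

The compounds below may be only part of what the source reports. "The series", "measured", "known", "first", "only" and "open" are said of these compounds alone.

Compound 1 `COc1ccc(Cl)c(-c2nnc3sc(Cc4c[nH]c5ccc(OC)cc45)nn23)c1` and compound 3 `COc1ccc(Cl)c(-c2nnc3sc(Cc4c(C)[nH]c5ccc(OC)cc45)nn23)c1` share one core. In a functional assay on the whole organism (strain Wistar Albino) for inhibition, with Rattus norvegicus as the target, read by paw edema, with a stated time of 1 h, at a dose of 20 mg/kg (on this read-out higher numbers stand for more inhibition at the one dose given (going by the name of the read-out) and lower numbers for less inhibition), compound 1 gives 6.1% and compound 3 gives 11.3%. The change between them is methyl in place of hydrogen on an aromatic carbon, and the step is a number 5.2 percentage points higher from compound 1 to compound 3 (within the scatter). Compound 2 `COc1ccc2[nH]cc(Cc3nn4c(Cc5ccc(OC)c(OC)c5)nnc4s3)c2c1` rests on a different core; the difference between the two cores is not broken down here. In this assay compound 2 gives 4.11%, a value within the scatter of both compound 1 and compound 3. Compound 4 `COc1ccc2[nH]c(C)c(Cc3nn4c(Cc5ccc(OC)c(OC)c5)nnc4s3)c2c1` carries the same change as compound 3, namely (methyl in place of hydrogen on an aromatic carbon). Because compound 3 gave 11.3% after this change, compound 4 is expected to move by about a number 4.9 percentage points higher from compound 2 to compound 4 (within the scatter) in this assay, a step that stays within the scatter. The estimate for compound 4 is 9%, with a range from 0% to 19%.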

Compound 4, a percentage reported as inhibition, in the whole organism at one dose (the size of the read-out at that dose, not a potency): 10.5%
Estimate against measurement, compound 4: 1.5 percentage points below; measured number inside the range.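

In this assay, methyl in place of hydrogen on an aromatic carbon leaves the reading a number 6.4 percentage points higher from compound 2 to compound 4 (within the scatter). Set beside the earlier step, the change carries from one core to the other at much the same size: the same change on two cores in this assay, a number 5.2 percentage points higher (within the scatter) from compound 1 to compound 3 and a number 6.4 percentage points higher (within the scatter) from compound 2 to compound 4, 1.2 percentage points apart, within the scatter of two such steps. This does not show that the methyl raises inhibition on either core, as each step lies within the scatter, and it says nothing about any core beyond these two.

The compounds shown leave open what an ethyl group, a longer chain or an amine would do at this place on the five-membered aromatic ring. They also leave open whether the two steps would stay alike at another dose or time.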